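The compounds below may be only part of what the source reports. "The series", "measured", "known", "first", "only" and "open" are said of these compounds alone.

Measured compounds:

- compound 1, `COC(=O)N(C)C(C)C#CCn1ccnc1`: 6.6 mg/kg
- compound 2, `COC(=O)N(C)C(C)C#CCN(C)C`: 11.8 mg/kg
- compound 3, `Cn1ccn(CC#CCn2ccnc2)c1=O`: 4.5 mg/kg

All three were run in a functional assay on the whole organism for agonist activity, with Mus musculus as the target; on this read-out higher numbers stand for an effect only at larger amounts of compound and lower numbers for an effect already at smaller amounts. Compound 1 and compound 2 share a core and differ by dimethylamino in place of 1H-imidazol-1-yl on a saturated chain carbon bound to a triple-bonded carbon; this gave a 1.8-fold higher number from compound 1 to compound 2 (0.25 log units; within the scatter). Compound 3 has a different core; the difference between the two cores is not broken down here. Compound 3 and compound 1 lie within the scatter of each other, while compound 3 and compound 2 are beyond it.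

Compound 4, `CN(C)CC#CCn1ccn(C)c1=O`, is not yet measured. It differs from compound 3 by dimethylamino in place of 1H-imidazol-1-yl on a saturated chain carbon bound to a triple-bonded carbon, the same change as from compound 1 to compound 2, at the same place. Because a 1.8-fold higher number from compound 1 to compound 2 (0.25 log units; within the scatter) was within the scatter, a step of similar size is expected, a 1.8-fold higher number from compound 3 to compound 4 (0.25 log units; within the scatter), resting on that single earlier pair. For compound 4 in this assay the estimate is 8 mg/kg, between 4.5 mg/kg and 15 mg/kg.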

Compound 4, dose for half-maximal effect: 5.4 mg/kg
Compound 4: middle estimate off by 1.5-fold (0.17 log units), on the high side; low and high end bracket the measured number.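

In this assay, dimethylamino in place of 1H-imidazol-1-yl gives a 1.2-fold higher number from compound 3 to compound 4 (0.08 log units; within the scatter), and the steps on the two cores agree: the same change on two cores in this assay, a 1.8-fold higher number (0.25 log units; within the scatter) from compound 1 to compound 2 and a 1.2-fold higher number (0.08 log units; within the scatter) from compound 3 to compound 4, 1.5-fold (0.17 log units) apart, within the scatter of two such steps. The change therefore carries from the core of compound 1 to the core of compound 3 as a step within the scatter, and neither step can be told from no change at all. Two pairs in one assay do not show how the change behaves on any further core, nor do they explain the size of the steps.

Still open, as far as these compounds go, is whether a cyclic amine such as pyrrolidine or morpholine, on a saturated chain carbon bound to a triple-bonded carbon, would give a step of similar size. The same question stands for a longer chain carrying the dimethylamino group.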